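This account rests on a few compounds, and the source may have more. Where it says the series, first, only, none or still open, it means among the compounds named here.

In a functional assay on PC-3 cells (Homo sapiens) for antiproliferative activity, read by MTT assay, with a stated time of 48 h (on this read-out lower numbers stand for stronger inhibition and higher numbers for weaker inhibition), compound 1 `Cc1ccc2nc(Nc3nc(Nc4ccc(S(N)(=O)=O)cc4)ncc3F)sc2c1` gives 4960 nM and stands as the lowest of the two numbers in this set. Compound 2 `Cc1cnc(Nc2ccc(S(C)(=O)=O)cc2)nc1Nc1nc2ccc(Cl)cc2s1` carries a methylsulfonyl group where compound 1 has a sulfonamide and a chloro where compound 1 has a methyl. In this assay compound 2 gives 13400 nM, a higher number and a gap that lies beyond the usual scatter. Compound 3 `Cc1cnc(Nc2ccc(C(C)C)cc2)nc1Nc1nc2ccccc2s1` reaches only a limit of the assay, > 50000 nM, in this assay; that is the limit described by the limit of > 50000 nM in this assay, at which 1 of the 3 values shown sits, and it gives no number to compare.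

The compound that follows, compound 4 `Cc1ccc2nc(Nc3nc(Nc4ccc(S(N)(=O)=O)cc4)ncc3C)sc2c1`, differs from compound 1 in one place: methyl in place of fluoro on an aromatic carbon, a methyl in place of fluoro on an aromatic carbon. Going by the values given here, no pair among the measured compounds shows this exchange on its own, so nothing in the data sets its size. With one small group replaced by another of the same atom count, the author expects a step in this assay that stays within the usual scatter, with no clear direction. The expected step is a 1.3-fold higher number from compound 1 to compound 4 (0.12 log units; within the scatter). Compound 4 is therefore estimated to give 6500 nM in this assay, with a range from 2500 nM to 17000 nM.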

Compound 4, half-maximal inhibitory concentration: 2710 nM
Compound 4: middle estimate off by 2.4-fold (0.38 log units), on the high side, within the range that was stated.
By their numbers in this assay, from the lowest: compounds 4 and 1 (each within the scatter of the next); then compound 2. At a limit, above all of these: compound 3.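

In this assay, going by these compounds alone, the first exchange in this set made in one place alone gives a 1.8-fold lower number from compound 1 to compound 4 (0.26 log units; within the scatter), with methyl in place of fluoro on an aromatic carbon of the six-membered aromatic ring with 2 nitrogen. Within the data shown here, this position, ortho to a large group and para to a large group, therefore accepts either of these two groups with values that stay within the scatter of each other, something the earlier compounds could not show, since none of them differs from another in one place only. Nothing measured in this set bears on why the two groups read alike.

The compounds shown leave open whether other groups at this position, such as an amine, a methoxy group or a longer chain, would also stay within the scatter or would move the number beyond it. They also leave open whether the exchange of fluoro for methyl would read the same on a compound that carries a methylsulfonyl group in place of the sulfonamide, as compound 2 does.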